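The source may report more compounds than this note shows. Statements on the series, on what has been measured and on what is new or still open speak of the compounds shown alone.

Compound 1 `COc1cc(-c2nccn2C(C)C)cc(OC)c1OC` carries an isopropyl on an aromatic nitrogen of the shared core. In a functional assay on HT-29 cells (Homo sapiens) for antiproliferative activity, read by MTT assay, with a stated time of 72 h (on this read-out higher numbers stand for weaker inhibition and lower numbers for stronger inhibition), compound 1 reads > 100000 nM, which is a limit and not a number. Compound 2 `COc1cc(-c2nccn2S(=O)(=O)c2ccccc2)cc(OC)c1OC` reads > 100000 nM in this assay, also a limit. For the measured compounds named here, the series so far stands at the limit of > 100000 nM in this assay, at which 2 of the 2 values shown sit, so no measured step is available. Compound 3 `COc1cc(-c2nccn2-c2ccc(C)cc2)cc(OC)c1OC` has 4-methylphenyl in place of isopropyl on that nitrogen: 4-methylphenyl in place of isopropyl on an aromatic nitrogen. A modest gain in inhibition is expected, though another limit remains possible, and the estimated step is an at least 3.3-fold lower number from compound 1 to compound 3 (0.52 log units; beyond the scatter). Compound 3 is estimated at 30000 nM, with an expected range of 2000 nM to 100000 nM.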

Compound 3, half-maximal inhibitory concentration: 1600 nM
Estimate against measurement, compound 3: 19-fold (1.27 log units) above; the measured number lies below the stated range.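

In this assay the substituent on the aromatic nitrogen of the shared core turns out to control whether a measurable number appears at all, with an at least 62-fold lower number from compound 1 to compound 3 (1.79 log units; beyond the scatter). Compound 3 is the only compound shown with a number, and the others remain at a limit: the limit of > 100000 nM in this assay, at which 2 of the 3 values shown sit.

Going by these compounds, what remains open is whether the six-membered aromatic ring alone accounts for the step or whether the methyl contributes as well. Plain phenyl on that nitrogen would separate the two, and an amine or a carboxylic acid in place of the methyl would test how much change the group tolerates.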